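Ester-to-acid change on two related cores at orexin receptor one

The source may hold more compounds than are shown below. What is called first, only, known or untested is meant among the compounds shown, and "the series" means these compounds.

Measured compounds:
compound 1 `COC(=O)c1cccc2c(C(=O)c3ccccc3)cc(C(=O)c3ccc(C(Cl)(Cl)Cl)cc3)c-2c1`: 10.4%
compound 2 `O=C(O)c1cccc2c(C(=O)c3ccccc3)cc(C(=O)c3ccc(C(Cl)(Cl)Cl)cc3)c-2c1`: 19.9%
compound 3 `CCOc1ccc(-c2cc(C(=O)c3ccccc3)c3ccc(C(=O)OC)ccc2-3)cc1`: 8.4%

In an assay on cells for displacement of a labelled ligand from Orexin/Hypocretin receptor type 1 (Homo sapiens), read by scintillation counting, with stated times of 10 min and 90 min, tested at 10 uM (on this read-out higher numbers stand for more inhibition at the one concentration tested (going by the name of the read-out) and lower numbers for less inhibition), compound 1 and compound 2 are separated by one change, (hydrogen in place of methyl on an oxygen next to a carbonyl group), and the step of a number 9.5 percentage points higher from compound 1 to compound 2 (within the scatter) is small. Compound 3 carries a different core; the difference between the two cores is not broken down here. Its value and that of compound 1 lie within the scatter of each other, while compound 2 sits beyond the scatter above compound 3.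

Compound 4 `CCOc1ccc(-c2cc(C(=O)c3ccccc3)c3ccc(C(=O)O)ccc2-3)cc1` has not yet been measured. It differs from compound 3 by hydrogen in place of methyl on an oxygen next to a carbonyl group, the same change seen between compound 1 and compound 2, at the same place. Because the earlier step of a number 9.5 percentage points higher from compound 1 to compound 2 (within the scatter) was small, the step for compound 4 is expected to be of similar size, a number 7.6 percentage points higher from compound 3 to compound 4 (within the scatter). Compound 4 is therefore estimated at 16%, between 3% and 30%.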

Compound 4, a percentage reported as inhibition, at one concentration (the size of the read-out at that concentration, not a potency): -24%
Compound 4: the middle estimate sits 40 percentage points above what was measured; measured number below the stated range.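

In this assay, the change from methoxycarbonyl to carboxy gives a number 32.4 percentage points lower from compound 3 to compound 4 (beyond the scatter). The outcome of this change on one core therefore does not predict its outcome on the other: the same change on two cores in this assay, a number 9.5 percentage points higher (within the scatter) from compound 1 to compound 2 and a number 32.4 percentage points lower (beyond the scatter) from compound 3 to compound 4, 41.9 percentage points apart, beyond the scatter of two such steps This rests on a single pair for each core, and it does not show why the two cores differ or how the change would behave on a further core.

The compounds shown leave open how other groups in the same place would behave on these two cores, such as an amide or an ethyl ester. They also leave open which part of the difference between the cores goes with the reversal.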